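The source may report more compounds than this note shows. Statements on the series, on what has been measured and on what is new or still open speak of the compounds shown alone.

The measured compounds:

Compound 1, `COc1ccc(OC)c(-c2cc(-c3ccccc3)nn2-c2ccc(S(=O)(=O)NC(C)=O)cc2)c1`, gives 42600 nM in a functional assay on cells (Cancer cell lines, Homo sapiens) for cytotoxicity, read by sulforhodamine B assay, with a stated time of 48 h; on this read-out lower numbers stand for stronger inhibition of growth and higher numbers for weaker inhibition of growth.
Compound 2, `Oc1ccc(O)c(-c2cc(-c3ccccc3)nn2-c2ccccc2)c1`, gives 71200 nM in this assay.
Compound 3, `Oc1ccc(O)c(-c2cc(-c3ccc(Cl)cc3)nn2-c2ccccc2)c1`, gives 34600 nM in this assay.

Compound 3 holds the lowest number of the three, though its gap to compound 1 lies within the scatter; only compound 2 stands beyond the scatter from it, and that single step, a 2.1-fold lower number from compound 2 to compound 3 (0.31 log units; beyond the scatter), is the one shown change with a firm size.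

Compound 4, `NS(=O)(=O)c1ccc(-n2nc(-c3ccc(Cl)cc3)cc2-c2cc(O)ccc2O)cc1`, is the next compound to be measured in this assay. It differs from compound 3 in one place: sulfamoyl in place of hydrogen on an aromatic carbon, on an aromatic carbon of a six-membered aromatic ring of carbon only, para to a large group, which read one bond further out is phenyl to 4-sulfamoylphenyl. Among the measured compounds shown here, no measured pair isolates this change. Compound 1 carries an acylated sulfonamide on the same ring, but its two further differences from compound 3 keep that pair from speaking to it; its number and that of compound 3 sit within the scatter of each other. For the measured compounds named here, the expectation for compound 4 therefore rests on no direct precedent: a step of a 1.3-fold lower number from compound 3 to compound 4 (0.12 log units; within the scatter) is estimated, which is within the scatter. Compound 4 is expected to give about 26000 nM, with a range from 8000 nM to 75000 nM.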

Compound 4, concentration for total growth inhibition: 35500 nM
Compound 4: the middle estimate sits 1.4-fold (0.14 log units) below what was measured; the measured number falls inside the stated range.
By their numbers in this assay, from the lowest: compounds 3, 4, 1 and 2 (each within the scatter of the next, the first and the last beyond it).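

Sulfamoyl on an aromatic carbon para to a large group, read one bond further out as phenyl to 4-sulfamoylphenyl, gives a direct reading at this position in this assay that no earlier pair offered: a 1.0-fold higher number from compound 3 to compound 4 (0.01 log units; within the scatter), so the two compounds cannot be told apart. This position therefore takes sulfamoyl in place of hydrogen with no step beyond the scatter, at least on the background carrying the chloro group, and the chloro step, a 2.1-fold lower number from compound 2 to compound 3 (0.31 log units; beyond the scatter), remains the only single-place change shown with a firm size. No measurement at hand bears on why the number holds with this substitution.

The compounds shown leave open how a carboxylic acid, an amine or a methylsulfonyl group would read at this same place, and whether sulfamoyl would read the same on the background without the chloro group. They also leave the acylated sulfonamide of compound 1 unresolved, since its further differences from compound 4 keep its part from being separated from that of the two methoxy groups.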